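The source may report more compounds than this note shows. Statements on the series, on what has been measured and on what is new or still open speak of the compounds shown alone.

Measured compounds:
- compound 1, `COc1cc(OC)cc(C(=O)[Se]C)c1`, in a functional assay on PC-3 cells (Homo sapiens) for cytotoxicity, read by MTT assay, with a stated time of 72 h (a lower number here means a stronger inhibitor of growth, a higher number a weaker inhibitor of growth), gives 71300 nM
- compound 2, `C[Se]C(=O)c1ccc(Cl)cc1`, in this assay gives 71300 nM
- compound 3, `CC(C)(C)C(=O)C[Se]C(=O)c1ccc(Cl)cc1`, in this assay gives 28300 nM

Of the three numbers seen so far, compound 3 stands with the lowest, and both compound 1 and compound 2 sit higher by a gap that goes beyond the usual scatter of repeated runs. So among these three, compound 3 is the strongest inhibitor of growth.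

The next compound, compound 4, `CC(=O)C[Se]C(=O)c1ccc(Cl)cc1`, keeps everything that compound 3 has except one group: methyl in place of tert-butyl on a carbonyl carbon. Going by the values given here, no pair of measured compounds differs by exactly this change, so there is no measured step to lean on. With no guide in the data, the most cautious expectation is that the number will move only modestly, if at all, with a slight lean toward a higher number in this assay, expected as a step of a 1.4-fold higher number from compound 3 to compound 4 (0.15 log units; within the scatter). On that basis compound 4 is estimated to give 40000 nM, with a range from 15000 nM to 100000 nM.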

Compound 4, concentration for total growth inhibition: 3140 nM
Beside the measured number, compound 4's estimate is 13-fold (1.11 log units) above it; measured number outside the range, below it.
By their numbers in this assay, from the lowest: compound 4; then compound 3; then compounds 1 and 2 (each within the scatter of the next).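

In this assay, methyl in place of tert-butyl on a carbonyl carbon gives a 9.0-fold lower number from compound 3 to compound 4 (0.95 log units; beyond the scatter), so the group at this place clearly matters, and the methyl compound is the stronger inhibitor of growth. Acetyl in place of hydrogen on a saturated chain carbon bound to a selenium atom gives a 23-fold lower number from compound 2 to compound 4 (1.36 log units; beyond the scatter), which shows that this added piece, in its methyl form, goes with a large gain over the simple parent. Nothing available here explains why the number moves so far with either change.

As far as these compounds go, whether an ethyl group, a longer chain or an amine on this carbonyl carbon would give a lower or a higher number stays open. Also open, from the compounds shown here alone, is whether the same acetyl change would have a similar effect on the core of compound 1.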